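A Bromo Group Added to the Benzyl Ring

The compounds below may be only part of what the source reports. "The series", "measured", "known", "first", "only" and "open" are said of these compounds alone.

Of the compounds shown here, two have been measured so far. Compound 1 `C#CCOc1ccc(/C=C/C(=O)c2ccc(OC)cc2)cc1` and compound 2 `O=C(/C=C/c1ccc(OCc2cn(Cc3ccccc3)nn2)cc1)c1ccc(Br)cc1` were both tested in a functional assay on A549 cells (Homo sapiens) for inhibition, read by MTT assay, with a stated time of 48 h, tested at 10 uM; a higher number here means more inhibition of growth at the concentration tested, a lower number less inhibition of growth. In this assay compound 1 gives 27%. In this assay compound 2 gives 34%, the higher of the two numbers, although the gap to compound 1 lies within the usual scatter, so the two cannot be told apart. These two compounds differ from each other at several places, so nothing can be said about what any single change between them does.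

Compound 3 `O=C(/C=C/c1ccc(OCc2cn(Cc3cccc(Br)c3)nn2)cc1)c1ccc(Br)cc1` has not been measured. It differs from compound 2 in one place: bromo in place of hydrogen on an aromatic carbon. Going by the values given here, no pair of measured compounds shows what such a swap does here, so there is no measured step to lean on. Because compound 2 gives 34% and the change merely swaps a hydrogen for a bromo group on the benzyl ring, only a small shift is expected, none beyond the scatter. The estimated step is a number 2 percentage points higher from compound 2 to compound 3 (within the scatter). Compound 3 is expected to give 36% in this assay, within a range from 20% to 52%.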

Compound 3, percent growth inhibition at one concentration: 44%
The estimate for compound 3 lay 8 percentage points below the measured number; the measured number falls inside the stated range.
By their numbers in this assay, from the lowest: compounds 1, 2 and 3 (each within the scatter of the next, the first and the last beyond it).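

Going by these compounds alone, compound 2 and compound 3 give the first measured step that comes from a change in one place: in this assay, putting bromo in place of hydrogen on the benzyl ring, which turns benzyl into 3-bromobenzyl, gives a number 10 percentage points higher from compound 2 to compound 3 (within the scatter) and so leaves the two compounds impossible to tell apart. This shows that the aromatic carbon of this ring can carry a bromo group, one heavy atom with no charge, without a loss of growth inhibition that stands clear of the scatter, though it does not establish a real gain either. Nothing measured here bears on why the step has this size, so no explanation can be offered for this position.

One small step at one test concentration says little about how far this ring can be changed, and repeat measurements would be needed to settle whether the step is real. Going by these compounds, whether a different group on the same carbon, such as an amine, a carboxylic acid or a longer chain, would move growth inhibition beyond the scatter remains open.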